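This account rests on a few compounds, and the source may have more. Where it says the series, first, only, none or still open, it means among the compounds named here.

Working notes on the series. Compound 1 `c1cc(N2CCCCC2)nc(Nc2ccc(Oc3ncnc4sccc34)cc2)n1` gives 40.4% in a functional assay on MDA-MB-231 cells (Homo sapiens) for inhibition, read by MTT assay, with a stated time of 72 h, tested at 20 uM; on this read-out lower numbers stand for less inhibition and higher numbers for more inhibition at the one concentration tested (going by the name of the read-out). Compound 2 `CN(c1ccc(Oc2ncnc3ccsc23)cc1)c1nccc(N2CCCC2)n1` gives 38% in this assay. Compound 3 `CN(c1ccc(Oc2ncnc3sccc23)cc1)c1nccc(N2CCCC2)n1` gives 31% in this assay. This is the lowest of the three numbers, yet its gaps to compound 2 and to compound 1 both lie within the scatter, so the three compounds are not separated on this read-out. Within the data shown here, the only single-place step measured so far, a number 7 percentage points lower from compound 2 to compound 3 (within the scatter), exchanges the shared core and stays within the scatter.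

Compound 4 `c1cc(N2CCCC2)nc(Nc2ccc(Oc3ncnc4sccc34)cc2)n1` has not been measured. From compound 3 it differs by hydrogen in place of methyl on a nitrogen on an aromatic ring. Among the measured compounds shown here, no measured step changes this nitrogen on its own: compound 1 and compound 3 differ at this nitrogen and also in a second place, and their two values lie within the scatter of each other. Nothing in the numbers points to a shift beyond the scatter, so the expected step of a number 4 percentage points higher from compound 3 to compound 4 (within the scatter) is set near zero. Compound 4 is therefore expected to give about 35% in this assay, with a range from 20% to 50%.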

Compound 4, a percentage reported as inhibition, at one concentration (the size of the read-out at that concentration, not a potency): 24.7%
The estimate for compound 4 lay 10.3 percentage points above the measured number; the range from low to high includes it.
By their numbers in this assay, from the lowest: compounds 4, 3, 2 and 1 (each within the scatter of the next, the first and the last beyond it).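

In this assay, the nitrogen on an aromatic ring now has a step of its own: hydrogen in place of methyl gives a number 6.3 percentage points lower from compound 3 to compound 4 (within the scatter) and so does not separate the two compounds. Among these compounds, the first step beyond the scatter comes from the other position, where pyrrolidin-1-yl in place of piperidin-1-yl on an aromatic carbon gives a number 15.7 percentage points lower from compound 1 to compound 4 (beyond the scatter) and is modest in size, resting on this single pair. Nothing available explains either step.

On that aromatic carbon the compounds shown carry only these two saturated rings, so the effect of a morpholine ring or a dimethylamino group remains open. At the nitrogen only hydrogen and methyl appear, which leaves an ethyl group or a longer chain open as well.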